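The source may hold more compounds than are shown below. What is called first, only, known or untested is meant among the compounds shown, and "the series" means these compounds.

Measured so far in an ADME assay (liver) for metabolic stability, with Liver microsome (Rattus norvegicus) as the target, using microsomes; a lower number here means slower removal, a higher number faster removal of the compound:
- compound 1 `c1ccc(CNc2nnc(-c3c[nH]c4ncccc34)o2)cc1`: 40 mL.min-1.g-1
- compound 2 `Fc1cccc(CNc2nnc(-c3c[nH]c4ncccc34)o2)c1`: 71 mL.min-1.g-1
- compound 3 `c1cnc2[nH]cc(-c3nnc(NCc4ccncc4)o3)c2c1`: 37 mL.min-1.g-1

Compound 1 holds no separate place among these values. The smallest of its steps is a 1.1-fold lower number from compound 1 to compound 3 (0.03 log units; within the scatter), and the largest is a 1.8-fold higher number from compound 1 to compound 2 (0.25 log units; within the scatter). Going by the values given here, the remaining pair gives a 1.9-fold lower number from compound 2 to compound 3 (0.28 log units; within the scatter), so the series so far shows no measured step beyond the scatter.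

Compound 4 `c1ccc([C@H](Nc2nnc(-c3c[nH]c4ncccc34)o2)C2CC2)cc1` keeps the core of compound 1 and differs from it as follows: cyclopropyl in place of hydrogen on a saturated chain carbon bound to an aromatic carbon and a nitrogen on an aromatic ring. The change is cyclopropyl in place of hydrogen on a saturated chain carbon bound to an aromatic carbon and a nitrogen on an aromatic ring.

Among the compounds with values here, none of the measured steps adds a group at that carbon. All of them alter the aromatic group instead, so they bear on this change only indirectly. Within the data shown here, the closest guide is compound 2, the only case where a group replaces a hydrogen on compound 1, with a 1.8-fold higher number from compound 1 to compound 2 (0.25 log units; within the scatter). On that thin basis, a modest move to a higher number is expected in this assay, probably not beyond the scatter, and the range is kept wide. The expected step is a 1.5-fold higher number from compound 1 to compound 4 (0.18 log units; within the scatter). For compound 4 the estimated value is 60 mL.min-1.g-1, with an expected range of 25 mL.min-1.g-1 to 140 mL.min-1.g-1.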

Compound 4, intrinsic clearance in microsomes: 31 mL.min-1.g-1
Compound 4: the middle estimate sits 1.9-fold (0.29 log units) above what was measured, within the range that was stated.
By their numbers in this assay, from the lowest: compounds 4, 3, 1 and 2 (each within the scatter of the next, the first and the last beyond it).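

In this assay, cyclopropyl in place of hydrogen on the saturated chain carbon bound to an aromatic carbon and a nitrogen on an aromatic ring gives a 1.3-fold lower number from compound 1 to compound 4 (0.11 log units; within the scatter). Going by these compounds alone, this is the first reading at that carbon rather than on the aromatic group, and it shows that a group of 3 heavy atoms, carrying a three-membered non-aromatic ring, can stand there with the number remaining within the scatter of compound 1. No measurement on hand accounts for this outcome, so the step stands as an observation only.

From the compounds shown here alone, the reading covers one substituent and the single stereo form drawn for compound 4, so the opposite form at that carbon remains open, as do a methyl, a longer chain, an amine or a carboxylic acid at the same place. Also open, going by these compounds, is whether cyclopropyl at this carbon gives a similar result when 3-fluorophenyl or pyridin-4-yl stands in place of phenyl, since compound 4 carries it only alongside the phenyl group of compound 1.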